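A group swap on an inactive compound

The source may hold more compounds than are shown below. What is called first, only, known or untested is meant among the compounds shown, and "the series" means these compounds.

In a functional assay on A549 cells (Homo sapiens) for antiproliferative activity, read by MTT assay (a lower number here means a stronger inhibitor, a higher number a weaker inhibitor), compound 3 `CC1(C)CCc2c(ccc(C(=O)/C=C/c3ccc(OCc4cn(-c5ccc(Cl)cc5)nn4)cc3)c2O)O1` is reported as "not active" (no number reported), so there is no number to start from. Compound 4 `Cc1c(-n2cc(COc3ccc(/C=C/C(=O)c4ccc5c(c4O)CCC(C)(C)O5)cc3)nn2)cccc1[N+](=O)[O-]` differs from it in one place: 2-methyl-3-nitrophenyl in place of 4-chlorophenyl on an aromatic nitrogen. The same swap, 2-methyl-3-nitrophenyl in place of 4-chlorophenyl on an aromatic nitrogen, has been measured once, on a pair with a different core. There, compound 1 `CC1(C)CCc2cc(C(=O)/C=C/c3ccc(OCc4cn(-c5ccc(Cl)cc5)nn4)cc3)c(O)cc2O1` gives 75500 nM and compound 2 `Cc1c(-n2cc(COc3ccc(/C=C/C(=O)c4cc5c(cc4O)OC(C)(C)CC5)cc3)nn2)cccc1[N+](=O)[O-]` gives 65900 nM. That swap amounts to a 1.1-fold lower number from compound 1 to compound 2 (0.06 log units; within the scatter), so no change beyond the scatter is expected in this assay, and compound 4 will probably also be reported without a number. Should a number appear, compound 4 is estimated at 100000 nM, with an expected range of 50000 nM to 200000 nM.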

Compound 4, half-maximal inhibitory concentration: "not active" (no number reported)
No number was reported for compound 4; the estimate stays without a comparison.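

In this assay, compound 3 and compound 4 both carry no number, so no step can be read between them. On these data alone, whether the swap changes activity on this core stays open. No evidence shown bears on this result.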